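Dipropylamino for iodophenylamino on the quinone-type core

A few compounds are considered here, and "the series" means these few. Any claim that something is new, unique, unknown or untested is made for them only; others in the source may bear on it.

Among the compounds with values here, compound 1 `O=C1C=C(Nc2ccc(I)cc2)C(=O)c2c1nc1n2[C@H]2OC[C@@H](O)[C@H]2OC1` holds the only number so far: in a functional assay on HeLa cells (Homo sapiens) for inhibition, read by sulforhodamine B assay (a lower number here means a stronger inhibitor, a higher number a weaker inhibitor), compound 1 gives 4070 nM. Compound 2 `COc1cccc(NC2=CC(=O)c3c(nc4n3[C@H]3OC[C@@H](O)[C@H]3OC4)C2=O)c1` returns only a limit in this assay, > 8000 nM, which is the assay ceiling rather than a value (the limit of > 8000 nM in this assay, at which 1 of the 2 values shown sits). Compound 3 `CCCN(CCC)C1=CC(=O)c2nc3n(c2C1=O)[C@H]1OC[C@@H](O)[C@H]1OC3` is not yet measured; it differs from compound 1 by dipropylamino in place of (4-iodophenyl)amino on a double-bonded ring carbon. Within the data shown here, no measured pair tells how such an exchange shifts this assay, so the step from compound 1 to compound 3 is expected to be small and, if anything, toward weaker inhibition. Compound 3 is expected near 6000 nM, between 2000 nM and 20000 nM. The expected step is a 1.5-fold higher number from compound 1 to compound 3 (0.17 log units; within the scatter).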

Compound 3, half-maximal inhibitory concentration: > 16000 nM
Compound 3 was reported as a limit (the forecaster's own chance of this, stated with the estimate: 35%); at least 2.6-fold (0.42 log units) between middle value and limit.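

Putting dipropylamino in place of (4-iodophenyl)amino on the double-bonded ring carbon gives an at least 3.9-fold higher number from compound 1 to compound 3 (0.59 log units; beyond the scatter) in this assay. Within the data shown here, this is the first step that can be read at this position, and it shows that the position is not indifferent to this exchange. The step is only a lower bound, because the figure for compound 3 is a limit: the limit of > 16000 nM in this assay, at which 1 of the 3 values shown sits.

The exchange removes the aromatic ring and the hydrogen-bond donor together, so the two remain unseparated. Propylamino, which keeps the amine hydrogen without a ring, and piperidine, a ring without that hydrogen, would pull them apart.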